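The source may hold more compounds than are shown below. What is called first, only, known or untested is meant among the compounds shown, and "the series" means these compounds.

Measured so far in an ADME assay on MT4 cells (Homo sapiens) for cytotoxicity, read by MTT assay, with a stated time of 4 days; a lower number here means that less compound is tolerated, a higher number that more compound is tolerated:
- compound 1 `CCOC(=O)c1cnc(N2CCN(Cc3ccccc3C(F)(F)F)CC2)nc1Oc1c(C)cc(-c2ccc(C#N)cc2)cc1C` gives > 125000 nM, which is a limit of the assay and not a number.
- compound 2 `CCOC(=O)c1cnc(N2CCN(Cc3cccc(F)c3)CC2)nc1Oc1c(C)cc(-c2ccc(C#N)cc2)cc1C` gives > 125000 nM, again a limit.
- compound 3 `CCOC(=O)c1cnc(N2CCN(Cc3cccc([N+](=O)[O-])c3)CC2)nc1Oc1c(C)cc(-c2ccc(C#N)cc2)cc1C` gives > 125000 nM, again a limit.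

Compound 3 therefore stands at the limit of this assay: no number is known for it, and it shares this position with the other two, as the limit of > 125000 nM in this assay, at which 3 of the 3 values shown sit, records. The next compound, compound 4 `CCOC(=O)c1cnc(N2CCN(Cc3ccccc3[N+](=O)[O-])CC2)nc1Oc1c(C)cc(-c2ccc(C#N)cc2)cc1C`, is still to be measured in this assay. It differs from compound 3 in one place: 2-nitrophenyl in place of 3-nitrophenyl on a saturated chain carbon bound to an amine nitrogen in a ring.

For the measured compounds named here, three measured steps touch the same part of the molecule, and all of them sit between limits. In this assay, a step that the two limits leave unreadable from compound 1 to compound 2; a step that the two limits leave unreadable from compound 1 to compound 3; and a step that the two limits leave unreadable from compound 2 to compound 3. None of these gives a readable size or direction, so the measured data carry no information on how the change in compound 4 might shift this assay, and no step beyond the scatter can be argued for.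

Compound 4 is therefore expected to sit at the limit as well, estimated at 125000 nM with a range from 60000 nM to 250000 nM. The step this estimate implies is expected to be a number no higher from compound 3 to compound 4 (the limit leaves the size open).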

Compound 4, half-maximal cytotoxic concentration: >= 78700 nM
Compound 4 ended at the assay's limit (the forecaster's own chance of this, stated with the estimate: 85%); the middle value lies beyond the limit too.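

In this assay compound 4 gives >= 78700 nM, which is a limit of the assay and not a number. For the compounds shown here, compounds 1, 2 and 3 also stand at a limit, so no step from any of them to compound 4 can be read. The compounds shown leave open the actual half-maximal cytotoxic concentration of each compound, and whether 2-nitrophenyl in place of 3-nitrophenyl changes it at all.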